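From Fluoro to Methoxy on a Shared Core

The source may report more compounds than this note shows. Statements on the series, on what has been measured and on what is new or still open speak of the compounds shown alone.

In a functional assay on HepG2 cells (Homo sapiens) for antiproliferative activity, read by MTT assay, with a stated time of 24 h (on this read-out lower numbers stand for stronger inhibition and higher numbers for weaker inhibition), compound 3 `C=CCc1cc(-c2ccc(F)cc2)ccc1O` stands at a limit of the assay, > 100000 nM. Compound 1 `C=CCOc1ccc(-c2ccc(OC)cc2)cc1CC=C` also returns only a limit, > 100000 nM. Compound 2 `C=CC(C)(C)c1cc(-c2ccc(OC)cc2)ccc1O`, which carries methoxy, gives a number, 91000 nM. Compound 4 `C=CCc1cc(-c2ccc(OC)cc2)ccc1O` has methoxy in place of fluoro on an aromatic carbon, para to a large group (methoxy in place of fluoro on an aromatic carbon). Among the compounds with values here, no measured pair isolates this change. With compound 2 at 91000 nM, only a small step toward stronger inhibition is expected in this assay, perhaps none beyond the scatter. The estimated change is an at least 1.1-fold lower number from compound 3 to compound 4 (0.07 log units; that floor lies within the scatter). For compound 4 the expected value is 85000 nM, with an estimated range of 35000 nM to 150000 nM.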

Compound 4, half-maximal inhibitory concentration: > 100000 nM
Compound 4 was reported as a limit; the forecaster's own chance of this, stated with the estimate: 45%; at least 1.1-fold (0.07 log units) between middle value and limit.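

In this assay compound 4 still returns only a limit, so methoxy in place of fluoro on an aromatic carbon, para to a large group, does not by itself bring a number. Allyl in place of 1,1-dimethylprop-2-en-1-yl gives an at least 1.0-fold higher number from compound 2 to compound 4 (0.04 log units; that floor lies within the scatter) and nothing firmer can be said of that change. The steps from compound 3 and from compound 1 to compound 4 cannot be read: the limit of > 100000 nM in this assay, at which 3 of the 4 values shown sit.

Going by these compounds, whether an amine or a hydroxyl in place of methoxy at this position would give a number stays open, as does any ranking of compound 1, compound 3 and compound 4.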